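The compounds below may be only part of what the source reports. "The series", "measured", "known", "first", "only" and "open" are said of these compounds alone.

Measured so far in an assay on Sf9 cells for inhibition of protein deacetylase HDAC6 (Homo sapiens), read by fluorescence, with a stated time of 40 min, tested at 100 nM; a higher number here means more inhibition at the concentration tested (going by the name of the read-out), a lower number less inhibition:

Compound 1 `O=C(NO)c1ccc(NCc2nc(-c3ccc(Br)cc3)nn2-c2ccccc2)cc1` gives 54.7%.
Compound 2 `Cc1ccc(-n2nc(-c3ccccc3)nc2CNc2ccc(C(=O)NO)cc2)cc1` gives 60.7%.
Compound 3 `NC(=O)c1ccc(NCc2nc(-c3ccccc3)nn2-c2ccccc2)cc1` gives -4.4%.

Compound 2 stands highest of the three numbers in this assay, but its nearest neighbour, compound 1, lies within the scatter of it, so no order between compound 2 and compound 1 can be read from these values. For the measured compounds named here, compound 3 lies far below both, beyond the scatter, and is the one compound of the set that shows no inhibition at the tested concentration.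

Compound 4 `O=C(NO)c1ccc(NCc2nc(-c3ccccc3)nn2-c2ccc(Cl)cc2)cc1` is not yet measured. It differs from compound 2 in one place: chloro in place of methyl on an aromatic carbon, on an aromatic carbon of a six-membered aromatic ring of carbon only, para to a large group. Going by the values given here, no step between two measured compounds of this kind is available, so the expectation rests on compound 2 alone, whose value 60.7% sets the reference point. The replacement of one heavy atom by one heavy atom, with no change in ring count, donors, acceptors or charge, is expected to give no step beyond the scatter in this assay, in either direction. The expected step of a number 2.7 percentage points lower from compound 2 to compound 4 (within the scatter) is estimated as essentially flat. For compound 4 the estimate is 58%, with a range from 40% to 75%.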

Compound 4, a percentage reported as inhibition, at one concentration (the size of the read-out at that concentration, not a potency): 55.4%
The estimate for compound 4 lay 2.6 percentage points above the measured number; measured number inside the range.
By their numbers in this assay, from the lowest: compound 3; then compounds 1, 4 and 2 (each within the scatter of the next).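

In this assay, chloro in place of methyl on an aromatic carbon, para to a large group, gives a number 5.3 percentage points lower from compound 2 to compound 4 (within the scatter). For the compounds shown here, this is the first step read at this position, and it shows that the exchange of 4-methylphenyl for 4-chlorophenyl leaves the inhibition at the tested concentration unresolved from that of the methyl compound, so this position accepts either of these two single-atom substituents on this core. Nothing at hand explains the size of this step.

On these data alone, whether the position stays as undemanding for groups of another kind, such as an amine, a carboxylic acid or a longer alkyl chain, remains open. Since this step rests on one pair at one concentration, it also leaves open whether compound 2 and compound 4 would match in potency.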